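Thiophene for Furan on an Isopropyl Ester Core

The source may hold more compounds than are shown below. What is called first, only, known or untested is meant among the compounds shown, and "the series" means these compounds.

Of the compounds shown here, three of a shared core have been measured, and a fourth awaits its number. Compound 2 `CCOC(=O)C1=C(C)N/C(=N\C#N)NC1c1ccco1` carries a furan-2-yl group and an ethyl ester; in an assay on HEK293 cells for displacement of a labelled ligand from adenosine receptor A2b (Homo sapiens), with a stated time of 30 min (on this read-out lower numbers stand for stronger inhibition and higher numbers for weaker inhibition), compound 2 gives 900 nM. Compound 1 `CCOC(=O)C1=C(C)N/C(=N\C#N)NC1c1cccs1` differs from compound 2 by thiophen-2-yl in place of furan-2-yl on a saturated ring carbon and in this assay compound 1 gives 51 nM, a step of an 18-fold lower number from compound 2 to compound 1 (1.25 log units; beyond the scatter). Compound 3 `CC1=C(C(=O)OC(C)C)C(c2ccco2)N/C(=N/C#N)N1` differs from compound 2 by methyl in place of hydrogen on a saturated chain carbon bound to an oxygen next to a carbonyl group and a saturated chain carbon; in this assay compound 3 gives 24.3 nM, a step of a 37-fold lower number from compound 2 to compound 3 (1.57 log units; beyond the scatter). Compound 3 thus holds the lowest number of the three measured, with compound 1 nearest.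

Compound 4 `CC1=C(C(=O)OC(C)C)C(c2cccs2)N/C(=N/C#N)N1` has not yet been measured. It differs from compound 3 by thiophen-2-yl in place of furan-2-yl on a saturated ring carbon. This is the same kind of change as that from compound 2 to compound 1, but the surroundings differ: in the earlier pair the place sits next to the ring atom that bears an ethoxycarbonyl group, whereas here it sits next to the ring atom that bears an isopropoxycarbonyl group. Resting on the earlier step of an 18-fold lower number from compound 2 to compound 1 (1.25 log units; beyond the scatter) from compound 2 to compound 1, but allowing that the second change may not carry its full weight when laid on the already low number of compound 3, compound 4 is expected to show a step of an 8.1-fold lower number from compound 3 to compound 4 (0.91 log units; beyond the scatter). Compound 4 is therefore estimated at 3 nM, with a range expected between 0.8 nM and 12 nM.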

Compound 4, inhibition constant: 349 nM
Beside the measured number, compound 4's estimate is 120-fold (2.07 log units) below it; the measured number lies above the stated range.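

In this assay, the swap of thiophen-2-yl for furan-2-yl does not carry from the core with the ethoxycarbonyl group to the core with the isopropoxycarbonyl group, where it gives a 14-fold higher number from compound 3 to compound 4 (1.16 log units; beyond the scatter), so the direction of the step turns over: the same change on two cores in this assay, an 18-fold lower number (1.25 log units; beyond the scatter) from compound 2 to compound 1 and a 14-fold higher number (1.16 log units; beyond the scatter) from compound 3 to compound 4, 250-fold (2.40 log units) apart, beyond the scatter of two such steps. The methyl that turns the ethoxycarbonyl group into the isopropoxycarbonyl group behaves in the same way, giving a 6.8-fold higher number from compound 1 to compound 4 (0.84 log units; beyond the scatter) on the core with thiophen-2-yl, whereas on the core with furan-2-yl it lowered the number: the same change on two cores in this assay, a 37-fold lower number (1.57 log units; beyond the scatter) from compound 2 to compound 3 and a 6.8-fold higher number (0.84 log units; beyond the scatter) from compound 1 to compound 4, 250-fold (2.40 log units) apart, beyond the scatter of two such steps. Within these compounds the two changes therefore do not add up, and the effect of each depends on which partner is present, but a single set of four compounds does not show why this happens or whether the same dependence holds for other groups in this series.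

The compounds shown leave open how a methoxycarbonyl or a tert-butoxycarbonyl group would pair with furan-2-yl and thiophen-2-yl on the shared core. They also leave open whether a phenyl group on the same saturated ring carbon would do better with the ethoxycarbonyl group or with the isopropoxycarbonyl group.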